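A few compounds are considered here, and "the series" means these few. Any claim that something is new, unique, unknown or untested is made for them only; others in the source may bear on it.

Of the compounds shown here, three sharing one core have been measured in an ADME assay on the whole organism (plasma) for pharmacokinetics, with Rattus norvegicus as the target; a higher number here means faster removal of the compound, a lower number slower removal. Compound 1 (`CCS(=O)(=O)n1cc2c(n1)CN([C@H]1CO[C@H](c3cc(F)ccc3F)[C@@H](N)C1)C2`) gives 1.6 mL/min/kg, compound 2 (`CC(C)S(=O)(=O)n1cc2c(n1)CN([C@H]1CO[C@H](c3cc(F)ccc3F)[C@@H](N)C1)C2`) gives 7 mL/min/kg, and compound 3 (`CCC(=O)Nc1n[nH]c2c1CN([C@H]1CO[C@H](c3cc(F)ccc3F)[C@@H](N)C1)C2`) gives 60 mL/min/kg. Compound 3 therefore has the highest number of the three, and it stands clear of both others by more than the usual scatter.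

The next compound, compound 4 (`N[C@H]1C[C@@H](N2Cc3[nH]nc(NS(=O)(=O)C4CC4)c3C2)CO[C@@H]1c1cc(F)ccc1F`), alters one group of compound 3: cyclopropylsulfonyl in place of propanoyl on a nitrogen on an aromatic ring. Among the measured compounds shown here, no measured pair shows this swap directly. For the measured compounds named here, the only measured single change is a 4.4-fold higher number from compound 1 to compound 2 (0.64 log units; beyond the scatter), where a methyl replaces a hydrogen on the chain of a sulfonyl group. That step is modest, though beyond the scatter, and it is not the same kind of change.

Going by the values given here, compound 1 and compound 2 are also the only measured compounds that carry a sulfonyl group, as compound 4 will, although theirs is attached differently. Both sit far under compound 3. Two compounds are a weak guide, so a moderate fall is expected, not a full drop to their level. The estimated step is a 3.0-fold lower number from compound 3 to compound 4 (0.48 log units; beyond the scatter). For compound 4 the estimated clearance is 20 mL/min/kg, with an expected range from 6 mL/min/kg to 60 mL/min/kg.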

Compound 4, clearance: 24 mL/min/kg
The estimate for compound 4 lay 1.2-fold (0.08 log units) below the measured number; the measured number falls inside the stated range.
By their numbers in this assay, from the lowest: compound 1; then compound 2; then compound 4; then compound 3.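

In this assay, among the compounds shown here, the one direct reading at this place is a 2.5-fold lower number from compound 3 to compound 4 (0.40 log units; beyond the scatter), a modest step that is still beyond the usual scatter, so the group on this nitrogen on an aromatic ring does affect the number. The earlier step among the compounds with a sulfonyl group changed only the chain on that group, where the sulfonyl was attached differently, and so said nothing about this nitrogen. This swap changes two things together, bringing in both a sulfonyl in place of a carbonyl and a three-membered carbon ring in place of an open chain, and no available evidence explains the step or assigns it to either part.

The compounds shown leave open which part carries the step: cyclopropylcarbonyl on this same nitrogen would keep the ring without the sulfonyl, while ethylsulfonyl would keep the sulfonyl without the ring. They also leave open where the plain amino group, with neither propanoyl nor cyclopropylsulfonyl on its nitrogen, would fall in this assay.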